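Pyrrolidin-1-yl in place of anilino: working notes

The source may hold more compounds than are shown below. What is called first, only, known or untested is meant among the compounds shown, and "the series" means these compounds.

For the measured compounds named here, in a functional assay on MGC-803 cells (Homo sapiens) for inhibition, read by sulforhodamine B assay (on this read-out higher numbers stand for weaker inhibition and lower numbers for stronger inhibition), compound 1 `O=C1C(Nc2ccccc2)=CC(=O)c2c1nc1n2[C@H]2OC[C@@H](O)[C@H]2OC1` gives 1830 nM and compound 2 `CCc1ccc(NC2=CC(=O)c3nc4n(c3C2=O)[C@H]2OC[C@@H](O)[C@H]2OC4)cc1` gives 1290 nM (these two lie within the scatter of each other, so compound 1 cannot be separated from the only other measured compound). Going by the values given here, compound 3 `O=C1C(N2CCCC2)=CC(=O)c2c1nc1n2[C@H]2OC[C@@H](O)[C@H]2OC1` keeps the core of compound 1 and carries pyrrolidin-1-yl in place of anilino on a double-bonded ring carbon as its single change. Among the compounds with values here, both measured compounds keep a six-membered aromatic ring of carbon only in their amino group, so no measured pair shows what losing it does. A moderate step toward a higher number in this assay is expected, though a result within the scatter would not surprise. The expectation starts from compound 1 at 1830 nM and stays wide. The estimate implies a step of a 1.5-fold higher number from compound 1 to compound 3 (0.18 log units; within the scatter) as the expected outcome. For compound 3 the expected value is 2800 nM (estimated range 800 nM to 9000 nM).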

Compound 3, half-maximal inhibitory concentration: > 16000 nM
Compound 3 ended at the assay's limit; the forecaster's own chance of this, stated with the estimate: 5%; at least 5.7-fold (0.75 log units) between middle value and limit.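

In this assay, the group on this double-bonded ring carbon turns out to matter: pyrrolidin-1-yl in place of anilino gives an at least 8.7-fold higher number from compound 1 to compound 3 (0.94 log units; beyond the scatter). Compound 3 sits at a limit of the assay, > 16000 nM, which is not a number, so the size of the step is only a lower bound: the limit of > 16000 nM in this assay, at which 1 of the 3 values shown sits.
For the compounds shown here, compound 1 and compound 2 both keep the six-membered aromatic ring of carbon only and lie within the scatter of each other, so only this step shows that a change in the amino group at this place can go beyond the scatter.

The aromatic ring and the hydrogen-bond donor leave together in this step, so it cannot be assigned to either one. Cyclohexylamino, which keeps the amine hydrogen without the aromatic ring, and methyl(phenyl)amino, which keeps the aromatic ring without that hydrogen, would be the groups to separate the two.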